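Cytotoxicity notes: carboxy to methoxy on the shared core

The compounds below may be only part of what the source reports. "The series", "measured", "known", "first", "only" and "open" are said of these compounds alone.

Compound 1 `O=C(O)c1cc(-c2ccc(F)nc2F)nn(Cc2ccc(Cl)cc2)c1=O` is tested in an ADME assay on HepG2 2.2.15 cells (Homo sapiens) for cytotoxicity, read by MTT assay, with a stated time of 8 days; a lower number here means that less compound is tolerated, a higher number that more compound is tolerated. In this assay compound 1 gives > 100000 nM, which is a limit of the assay and not a number. Compound 2 `Cc1nc(-c2ccc(F)nc2F)cn(Cc2ccc(Cl)cc2)c1=O` likewise gives only a limit, > 100000 nM. Compound 3 `CN(C)c1ccc(-c2nn(Cc3ccc(C#N)cc3)c(=O)c3ccccc23)c(F)n1` gives 79200 nM. Going by the values given here, compound 1 thus sits at the limit of > 100000 nM in this assay, at which 2 of the 3 values shown sit, and no measured step links it to another compound in the set.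

Compound 4 `COc1cc(-c2ccc(F)nc2F)nn(Cc2ccc(Cl)cc2)c1=O` is not yet measured in this assay; it differs from compound 1 by methoxy in place of carboxy on an aromatic carbon. The step from compound 1 to compound 4 a step that the limit leaves unreadable from compound 1 to compound 4 is expected to be none beyond the scatter. Compound 4 is expected to give 150000 nM, between 50000 nM and 500000 nM, most likely reported again only as a limit.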

Compound 4, half-maximal cytotoxic concentration: 92200 nM
The estimate for compound 4 lay 1.6-fold (0.21 log units) above the measured number; the range from low to high includes it.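

Going by these compounds alone, with methoxy in place of carboxy on this aromatic carbon, compound 4 gives 92200 nM in this assay, the first number on the shared core that is not a limit. The change shows an at least 1.0-fold lower number from compound 1 to compound 4 (0.03 log units; that floor lies within the scatter). How much larger the step may be stays unreadable, since compound 1 gives only a limit: the limit of > 100000 nM in this assay, at which 2 of the 4 values shown sit.

Going by these compounds, whether an amine or a longer chain such as ethoxy at this position would give a number clearly apart from that of compound 4 remains open.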